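Swapping a para chloro for nitro on a cyanoacrylamide

The source may hold more compounds than are shown below. What is called first, only, known or untested is meant among the compounds shown, and "the series" means these compounds.

Compound 1 `Cc1ccc(/C=C(\C#N)C(=O)Nn2c(C)nc3ccc(C)cc3c2=O)cc1` gives 12000 nM in a functional assay on HepG2 cells (Homo sapiens) for cytotoxicity, read by MTT assay, with a stated time of 3 days; a lower number here means a stronger inhibitor, a higher number a weaker inhibitor.
Compound 2 `Cc1ccc2nc(C)n(NC(=O)/C(C#N)=C/c3ccc(Cl)cc3)c(=O)c2c1` gives 9000 nM in this assay.

For the measured compounds named here, only two compounds have been measured, and compound 2 holds the lower of the two numbers in this assay, though the step between them, a 1.3-fold lower number from compound 1 to compound 2 (0.12 log units; within the scatter), is within the scatter. Compound 3 `Cc1ccc2nc(C)n(NC(=O)/C(C#N)=C/c3ccc([N+](=O)[O-])cc3)c(=O)c2c1` has not been measured. It differs from compound 2 by nitro in place of chloro on an aromatic carbon, sitting on an aromatic carbon of a six-membered aromatic ring of carbon only, para to a large group. Going by the values given here, the only measured step, a 1.3-fold lower number from compound 1 to compound 2 (0.12 log units; within the scatter), also exchanges one group at this position, and it moved nothing beyond the scatter. Among the compounds with values here, no step involving nitro has been measured. The expectation is therefore a step of no change at the digits printed from compound 2 to compound 3 (within the scatter), with no direction beyond the scatter. Compound 3 is estimated at 9000 nM in this assay, within the range 3000 nM to 27000 nM.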

Compound 3, half-maximal inhibitory concentration: 10000 nM
For compound 3 the middle estimate is 1.1-fold (0.05 log units) below the measured one; the range from low to high includes it.
By their numbers in this assay, from the lowest: compounds 2, 3 and 1 (each within the scatter of the next).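

Exchanging 4-chlorophenyl for 4-nitrophenyl puts 3 heavy atoms and 2 hydrogen-bond acceptors where chloro had 1 heavy atom and none, yet in this assay it gives a 1.1-fold higher number from compound 2 to compound 3 (0.05 log units; within the scatter). Nitro in place of methyl gives a 1.2-fold lower number from compound 1 to compound 3 (0.08 log units; within the scatter), so methyl, chloro and nitro at this position now all lie within the scatter of one another, where the earlier compounds offered only a single such comparison. No measurement at hand accounts for this flat response.

The three compounds leave open whether any group at this position, such as an amine or a carboxylic acid, would give a step beyond the scatter. They also leave open whether the same flat response would hold if the shared core were changed elsewhere.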